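The compounds below may be only part of what the source reports. "The series", "measured", "known", "first", "only" and "open" are said of these compounds alone.

Measured so far in an assay on isolated protein for binding affinity to fibroblast growth factor 2 (Homo sapiens), read by surface plasmon resonance; a lower number here means tighter binding, a higher number weaker binding:
- compound 1 `CC(=O)N[C@H]1[C@@H](OC[C@@H](O)[C@@H](O)[C@H](O)[C@@H](O)CNc2cccc(NC(=O)CCCCC3CCSS3)c2)O[C@H](CO)[C@H](O)[C@@H]1O[C@@H]1O[C@H](C(=O)O)[C@@H](O)[C@H](O)[C@H]1OS(=O)(=O)O` — 62 nM
- compound 2 `CC(=O)N[C@H]1[C@@H](OC[C@@H](O)[C@@H](O)[C@H](O)[C@@H](O)CNc2cccc(NC(=O)CCCCC3CCSS3)c2)O[C@H](CO)[C@H](O)[C@@H]1O[C@@H]1O[C@H](C(=O)O)[C@@H](O)[C@H](OS(=O)(=O)O)[C@H]1O` — 25 nM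

For the measured compounds named here, of the two numbers so far, compound 2 carries the lower one. Its nearest neighbour is compound 1, and the gap between the two lies beyond the scatter, so compound 2 is the tighter binder of the pair. Both carry a single sulfooxy group on the shared core, at different places.

Compound 3 `CC(=O)N[C@H]1[C@@H](OC[C@@H](O)[C@@H](O)[C@H](O)[C@@H](O)CNc2cccc(NC(=O)CCCCC3CCSS3)c2)O[C@H](CO)[C@H](O)[C@@H]1O[C@@H]1O[C@H](C(=O)O)[C@@H](O)[C@H](OS(=O)(=O)O)[C@H]1OS(=O)(=O)O` has not yet been measured in this assay. Relative to compound 2 the change is sulfo in place of hydrogen on an oxygen on a saturated carbon, so that compound 3 carries the sulfooxy groups of both compound 1 and compound 2 at once. Going by the values given here, no step between measured compounds matches this change, so there is nothing to carry over directly; what can be said is that each single sulfooxy pattern has given a number in the low range, with compound 2 the lower of the two.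

The expectation for compound 3 is a small step down from compound 2, a 1.7-fold lower number from compound 2 to compound 3 (0.22 log units; within the scatter), within or just beyond the scatter. Compound 3 is estimated at 15 nM, with a range from 6 nM to 40 nM.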

Compound 3, dissociation constant: 95 nM
Estimate against measurement, compound 3: 6.3-fold (0.80 log units) below, and the stated range ends below it.
By their numbers in this assay, from the lowest: compound 2; then compounds 1 and 3 (each within the scatter of the next).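

In this assay, the hydroxy to sulfooxy change on the saturated carbon brings no gain when the other sulfooxy group is already present: the result is a 3.8-fold higher number from compound 2 to compound 3 (0.58 log units; beyond the scatter), so at this position a further sulfooxy group works against binding in the context of compound 2. Read from the other side, the same kind of change gives a 1.5-fold higher number from compound 1 to compound 3 (0.19 log units; within the scatter), so adding the second group to compound 1 produces no difference that can be told apart from scatter, and the two single patterns do not add up in either direction. Nothing measured here accounts for this lack of additivity.

The compounds shown leave open what either sulfooxy group is worth on its own, since the comparison with hydroxy at both places on the shared core is absent from this set. Also open, as far as these compounds go, is whether the outcome holds with the sulfooxy group on the hydroxymethyl group, or with a methyl ester in place of the carboxylic acid.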